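The compounds below may be only part of what the source reports. "The series", "measured", "known", "first", "only" and "open" are said of these compounds alone.

Working notes on the series. Among the compounds with values here, in an ADME assay on microsomes from liver (Mus musculus) for metabolic stability, read by LC-MS, with a stated time of 10 min, tested at 0.5 uM (on this read-out lower numbers stand for a less stable compound and higher numbers for a more stable compound), compound 1 (`c1ccc2c(c1)CN[C@H](CN(CCCN1CCNCC1)[C@H]1CCCc3cccnc31)C2`) gives 88%, the highest of the three numbers so far. Compound 2 (`CC(C)N1CCN(CCCN(C[C@H]2Cc3ccccc3CN2)[C@H]2CCCc3cccnc32)CC1`) gives 58% and compound 3 (`CCN1CCN(CCCN(C[C@H]2Cc3ccccc3CN2)[C@H]2CCCc3cccnc32)CC1`) gives 19%, both beyond the scatter from compound 1.

The next compound to read is compound 4 (`c1cnc2c(c1)CN[C@H](CN(CCCN1CCNCC1)[C@H]1CCCc3cccnc31)C2`), and its change from compound 1 is a group of 10 heavy atoms (8 carbon, 2 nitrogen; one six-membered non-aromatic ring with 1 hetero atom, one six-membered aromatic ring with 1 hetero atom) in place of a group of 10 heavy atoms (9 carbon, 1 nitrogen; one six-membered non-aromatic ring with 1 hetero atom, one six-membered aromatic ring of carbon only), on a saturated chain carbon bound to an amine nitrogen. In short, one six-membered aromatic ring of carbon only gives way to one six-membered aromatic ring with 1 hetero atom, and the rest of the molecule stays the same.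

Within the data shown here, the only measured single-place step is a number 39 percentage points lower from compound 2 to compound 3 (beyond the scatter). Among the measured compounds shown here, it is large, but it does not touch the group exchanged here, so it says nothing direct about this swap and shows only that one small change can move this assay a long way. For the measured compounds named here, no measured step covers the exchanged group itself.

No step beyond the scatter is therefore expected, and the estimated step is a number 3 percentage points lower from compound 1 to compound 4 (within the scatter). The range is kept wide and reaches mostly downward, as compound 1 at 88% already sits near the top of the scale. Compound 4 is expected at 85%, with an estimated range of 62% to 99%.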

Compound 4, percent of the compound remaining: 63%
For compound 4 the middle estimate is 22 percentage points above the measured one; low and high end bracket the measured number.
By their numbers in this assay, from the lowest: compound 3; then compounds 2 and 4 (each within the scatter of the next); then compound 1.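

In this assay, replacing the 1,2,3,4-tetrahydroisoquinolin-3-yl group with its counterpart carrying a six-membered aromatic ring with 1 hetero atom gives a number 25 percentage points lower from compound 1 to compound 4 (beyond the scatter) on the saturated chain carbon bound to an amine nitrogen. Within the data shown here, this is the first measured step at this position, and it shows that the read-out responds to a change of one ring atom in the aromatic ring while the heavy-atom count of the group and the rest of the molecule stay the same; the earlier step, a number 39 percentage points lower from compound 2 to compound 3 (beyond the scatter), lay in a different place and could not show this. No measurement at hand bears on what lies behind the new step.

The compounds shown leave open whether a fluorine, a chlorine or a methoxy group on the carbon-only aromatic ring of compound 1 would keep the read-out or lower it, and whether a six-membered aromatic ring with two nitrogens would extend the step. They also leave open whether the same ring exchange would have a similar size on the ethyl group of compound 3 or the isopropyl group of compound 2.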